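Methyl to trifluoromethyl: clearance across two cores

A few compounds are considered here, and "the series" means these few. Any claim that something is new, unique, unknown or untested is made for them only; others in the source may bear on it.

Measured so far:
compound 1 `Cc1ccc([C@H](C)NC(=O)Cn2nnc3ccccc3c2=O)nc1`: < 9.9 mL/min/kg
compound 2 `Cc1ccc([C@H](C)NC(=O)Cn2nnc3ccc(C)cc3c2=O)cc1`: 179 mL/min/kg
compound 3 `Cc1ccc([C@H](C)NC(=O)Cn2nnc3ccc(C(F)(F)F)cc3c2=O)cc1`: 435 mL/min/kg

The read-out is an ADME assay on microsomes from liver (Homo sapiens) for metabolic stability; on this read-out higher numbers stand for fast clearance and lower numbers for slow clearance. For compound 1 the reported value is not a number but a limit of the assay, namely (the limit of < 9.9 mL/min/kg in this assay, at which 1 of the 3 values shown sits). In this assay compound 2 gives 179 mL/min/kg and compound 3 gives 435 mL/min/kg. The change between them is trifluoromethyl in place of methyl on an aromatic carbon, and it made a 2.4-fold higher number from compound 2 to compound 3 (0.39 log units; beyond the scatter). The difference between the core of compound 1 and the core of compound 2 is not broken down here.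

Compound 4 `C[C@H](NC(=O)Cn1nnc2ccccc2c1=O)c1ccc(C(F)(F)F)cn1` is still to be measured in this assay. It differs from compound 1 by trifluoromethyl in place of methyl on an aromatic carbon. This is the same kind of change as that from compound 2 to compound 3, not the same one: there the group sits on a six-membered aromatic ring of carbon only, part of a fused or bridged system of two rings, meta to a fused ring and para to a fused ring; here it sits on a six-membered aromatic ring with 1 nitrogen, two atoms from the ring nitrogen, para to a large group. The starting point of compound 1 is known only as a limit, so the expectation is loose. The expected step is an at least 1.2-fold higher number from compound 1 to compound 4 (0.08 log units; that floor lies within the scatter), about the size of a 2.4-fold higher number from compound 2 to compound 3 (0.39 log units; beyond the scatter). For compound 4 the estimate is 12 mL/min/kg, with a range from 5 mL/min/kg to 35 mL/min/kg.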

Compound 4, clearance: < 9.9 mL/min/kg
Compound 4: a limit, no number (the forecaster's own chance of this, stated with the estimate: 40%); middle value at least 1.2-fold (0.08 log units) from the limit.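

In this assay, compound 4 reads as a limit of the assay, as compound 1 does, so no step for trifluoromethyl in place of methyl can be read between these two compounds: the limit of < 9.9 mL/min/kg in this assay, at which 2 of the 4 values shown sit.

The compounds shown leave open how large this change is on the core of compound 1, and how it compares with a 2.4-fold higher number from compound 2 to compound 3 (0.39 log units; beyond the scatter).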